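This account rests on a few compounds, and the source may have more. Where it says the series, first, only, none or still open, it means among the compounds named here.

Three urea compounds from one series have been measured. Compound 1 `CCCCCCCCc1ccc(NC(=O)Nc2c(C(C)C)cccc2C(C)C)cc1` gives 11 nM in an assay on isolated protein for inhibition of acyl-CoA:cholesterol acyltransferase (Oryctolagus cuniculus); a lower number here means a stronger inhibitor, a higher number a weaker inhibitor. Compound 2 `CC(C)c1cccc(C(C)C)c1NC(=O)Nc1ccccc1` gives 910 nM in this assay, and compound 3 `CCc1ccc(NC(=O)Nc2c(C(C)C)cccc2C(C)C)cc1` gives 100 nM in this assay. Compound 3 therefore stands between the other two: the step of a 9.1-fold higher number from compound 1 to compound 3 (0.96 log units; beyond the scatter) separates it from compound 1, and the step of a 9.1-fold lower number from compound 2 to compound 3 (0.96 log units; beyond the scatter) separates it from compound 2.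

The next compound, compound 4 `CC(C)c1cccc(C(C)C)c1NC(=O)Nc1ccc(C(C)(C)C)cc1`, is not yet measured. It differs from compound 3 in one place: tert-butyl in place of ethyl on an aromatic carbon.

Among the measured compounds shown here, two measured steps bear on this change. The step of a 9.1-fold lower number from compound 2 to compound 3 (0.96 log units; beyond the scatter) shows that adding a small alkyl group at this place gives a lower number, and the step of an 83-fold higher number from compound 1 to compound 2 (1.92 log units; beyond the scatter) shows that a much longer chain at the same place gives a far lower number still. Tert-butyl is larger than ethyl but carries fewer atoms than octyl, so a modest further fall in this assay is expected rather than a large one.

Compound 4 is expected to give about 40 nM in this assay, with a likely range from 15 nM to 120 nM. This estimate corresponds to an expected step of a 2.5-fold lower number from compound 3 to compound 4 (0.40 log units; beyond the scatter).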

Compound 4, half-maximal inhibitory concentration: 168 nM
Compound 4: middle estimate off by 4.2-fold (0.62 log units), on the low side, outside the stated range (above it).
By their numbers in this assay, from the lowest: compound 1; then compounds 3 and 4 (each within the scatter of the next); then compound 2.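

Placing tert-butyl where ethyl stood, on this aromatic carbon para to a large group, gives in this assay a 1.7-fold higher number from compound 3 to compound 4 (0.23 log units; within the scatter) and so the two groups cannot be told apart here, although tert-butyl carries more carbon. Tert-butyl still clearly beats a bare hydrogen at this place with a 5.4-fold lower number from compound 2 to compound 4 (0.73 log units; beyond the scatter) but it falls well short of octyl with a 15-fold higher number from compound 1 to compound 4 (1.18 log units; beyond the scatter) and that shows that adding carbon does not lower the number by itself. Among these four compounds only octyl, the longest group, stands clearly apart from both ethyl and tert-butyl, and nothing measured here explains why these groups behave as they do.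

The compounds shown leave open whether a straight chain of middling length, such as butyl or hexyl, would already come close to compound 1, and whether a long branched chain would behave like octyl or like tert-butyl. They also leave open how a chain carrying an ether oxygen, or a group such as an amine or a carboxylic acid, would fare at this same place.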